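The compounds below may be only part of what the source reports. "The series", "measured", "known", "first", "only" and "open" are said of these compounds alone.

Of the compounds shown here, two have so far been measured in an assay on membranes from liver for displacement of a labelled ligand from Glucagon receptor (Mus musculus), read by scintillation counting, with a stated time of 60 min; on this read-out higher numbers stand for weaker inhibition and lower numbers for stronger inhibition. Compound 1 `C[C@H](c1ccc(C(=O)NCCC(=O)O)cc1)N1C(=O)C(c2cccc(C3CC3)c2)=N[C@]12CC[C@@H](C(C)(C)C)CC2` gives 1700 nM in this assay, while compound 2 `CC(C)(C)CC[C@H](c1ccc(C(=O)NCc2nn[nH]n2)cc1)N1C(=O)C(c2cncc(Cl)c2)=N[C@]12CC[C@@H](C(C)(C)C)CC2` gives 84 nM in this assay. Compound 2 therefore holds the lower of the two numbers, and the gap up to compound 1 lies well beyond the usual scatter of repeated measurements, so compound 2 is the stronger of the two on this read-out.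

Compound 3 `CC(C)(C)CC[C@H](c1ccc(C(=O)NCc2nn[nH]n2)cc1)N1C(=O)C(c2ccc(F)cc2)=N[C@]12CC[C@@H](C(C)(C)C)CC2` has not yet been measured in this assay. It is derived from compound 2 by a single change: 4-fluorophenyl in place of 5-chloropyridin-3-yl on a carbon with a double bond to nitrogen. The group that leaves and the group that enters are of the same size, and the exchange trades a six-membered aromatic ring with one hetero atom and one hydrogen-bond acceptor for a six-membered aromatic ring of carbon only with no acceptor. Among the measured compounds shown here, no measured pair in this set shows such an exchange, so the data give no direct guide to its size. The step of a 1.8-fold higher number from compound 2 to compound 3 (0.25 log units; within the scatter) is expected to be small, at most a mild weakening close to the scatter. Compound 3 is therefore expected to give about 150 nM in this assay, within a range from 50 nM to 500 nM.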

Compound 3, half-maximal inhibitory concentration: 90 nM
Compound 3: the middle estimate sits 1.7-fold (0.22 log units) above what was measured; measured number inside the range.
By their numbers in this assay, from the lowest: compounds 2 and 3 (each within the scatter of the next); then compound 1.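

In this assay, 4-fluorophenyl in place of 5-chloropyridin-3-yl on a carbon with a double bond to nitrogen gives a 1.1-fold higher number from compound 2 to compound 3 (0.03 log units; within the scatter) and so leaves the two compounds indistinguishable on this read-out. This first pair differing in one place shows that, with the rest of compound 2 held fixed, a six-membered aromatic ring of carbon only and no hydrogen-bond acceptor reads the same here as a six-membered aromatic ring with one hetero atom and one hydrogen-bond acceptor. No measurement available here explains why these two groups read alike.

On these data alone, both groups are six-membered aromatic rings of the same size, so it remains open whether this position needs an aromatic ring at all, which a saturated cyclohexyl ring or a small methyl group in the same place would test. As far as these compounds go, it also remains open whether the chlorine or the fluorine matters on its own, a question that plain phenyl would address.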